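The source may hold more compounds than are shown below. What is called first, only, known or untested is meant among the compounds shown, and "the series" means these compounds.

Measured so far:
compound 1, `CC[C@@H](Nc1c(C#N)c(-c2ccc(-c3cccc(OC)c3)cc2)nc2cnccc12)C(N)=O`: 104 nm/s
compound 2, `CC[C@@H](Nc1c(C#N)c(-c2ccc(Br)cc2)nc2cnccc12)C(N)=O`: 202 nm/s

Among the compounds with values here, in an ADME assay on Caco-2 cells (Homo sapiens) for permeability, read by LC-MS, in the apical to basolateral direction, with a stated time of 2 h, tested at 2 uM (a lower number here means that the compound crosses the layer more slowly, a higher number that the compound crosses the layer faster), compound 2 gives 202 nm/s and compound 1 gives 104 nm/s; the single step between them, a 1.9-fold higher number from compound 1 to compound 2 (0.29 log units; within the scatter), stays within the scatter. Compound 3, `CC[C@@H](Nc1c(C#N)c(-c2ccc(-c3cccc(Cl)c3)cc2)nc2cnccc12)C(N)=O`, differs from compound 2 by 3-chlorophenyl in place of bromo on an aromatic carbon. Within the data shown here, the only measured step that bears on this change is a 1.9-fold higher number from compound 1 to compound 2 (0.29 log units; within the scatter), a swap of the same kind in the opposite sense that stayed within the scatter, so no step beyond the scatter is expected in this assay, at most a small decrease. Compound 3 is therefore expected to give about 120 nm/s, estimated between 60 nm/s and 240 nm/s, a step of a 1.7-fold lower number from compound 2 to compound 3 (0.23 log units; within the scatter).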

Compound 3, apparent permeability: 37 nm/s
The estimate for compound 3 lay 3.2-fold (0.51 log units) above the measured number; measured number below the stated range.
By their numbers in this assay, from the lowest: compound 3; then compounds 1 and 2 (each within the scatter of the next).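

In this assay, 3-chlorophenyl in place of bromo on this aromatic carbon, para to a large group, brings a step beyond the scatter (a 5.5-fold lower number from compound 2 to compound 3 (0.74 log units; beyond the scatter)), which the earlier pair did not show. The substituent on the added ring also counts: chloro in place of methoxy gives a step beyond the scatter as well (a 2.8-fold lower number from compound 1 to compound 3 (0.45 log units; beyond the scatter)), so the result depends on more than the swap of bromo for an aromatic ring. As far as these compounds go, whether an amine or a carboxylic acid on that added ring would shift the number remains open. Nothing at hand accounts for either step.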